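The compounds below may be only part of what the source reports. "The series", "measured", "known", "first", "only" and "open" are said of these compounds alone.

Measured so far: compound 1 `CN1CCN(c2ccn3c(-c4ccc(NC(=O)c5ccc([N+](=O)[O-])o5)cc4)cnc3c2)CC1` gives 2340 nM in a functional assay on AGS cells (Homo sapiens) for antiproliferative activity, read by CCK-8 assay, with a stated time of 72 h (on this read-out lower numbers stand for stronger inhibition and higher numbers for weaker inhibition), and compound 2 `CN1CCCN(c2ccn3c(-c4ccc(NC(=O)c5ccc([N+](=O)[O-])o5)cc4)cnc3c2)CC1` gives 2700 nM in this assay.

Compound 2 thus sits together with compound 1 inside the usual scatter, the step of a 1.2-fold higher number from compound 1 to compound 2 (0.06 log units; within the scatter) being small. Compound 3 `O=C(Nc1ccc(-c2cnc3ccccn23)cc1)c1ccc([N+](=O)[O-])o1` differs from compound 2 by hydrogen in place of 4-methyl-1,4-diazepan-1-yl on an aromatic carbon. Among the measured compounds shown here, the one measured step, a 1.2-fold higher number from compound 1 to compound 2 (0.06 log units; within the scatter), exchanges one amine ring for another and shows little effect; no measured step removes the amine ring altogether, so it bears on this change only loosely. The estimated step is a 1.3-fold higher number from compound 2 to compound 3 (0.11 log units; within the scatter), leaning toward weaker inhibition but with wide uncertainty. Compound 3 is expected near 3500 nM in this assay, between 1200 nM and 10000 nM.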

Compound 3, half-maximal inhibitory concentration: 360 nM
For compound 3 the middle estimate is 9.7-fold (0.99 log units) above the measured one; measured number outside the range, below it.
By their numbers in this assay, from the lowest: compound 3; then compounds 1 and 2 (each within the scatter of the next).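

Putting hydrogen on this aromatic carbon, opposite the ring nitrogen, in place of 4-methyl-1,4-diazepan-1-yl gives [ a 7.5-fold lower number from compound 2 to compound 3 (0.88 log units; beyond the scatter) ], and in place of 4-methylpiperazin-1-yl gives [ a 6.5-fold lower number from compound 1 to compound 3 (0.81 log units; beyond the scatter) ]. Whereas exchanging one amine ring for the other changed little, losing the ring altogether brings a step beyond the scatter in both cases, so compound 3 stands apart from compound 1 and compound 2. Nothing available here accounts for this difference.

As far as these compounds go, it remains open whether a small group such as methyl or methoxy on this carbon would stay close to compound 3. An open-chain amine such as dimethylamino could equally fall nearer compound 1 and compound 2.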